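The compounds below may be only part of what the source reports. "The series", "measured", "known", "first", "only" and "open" are said of these compounds alone.

Of the compounds shown here, two have been tested so far in a functional assay on MCF7 cells (Homo sapiens) for antiproliferative activity; on this read-out higher numbers stand for weaker inhibition and lower numbers for stronger inhibition. Compound 1, with the structure `C/C1=C\CC(C)(C)/C=C/C(=O)N(Cc2cn(CCOc3ccc(C(=O)/C=C/c4ccc(C)cc4)c(O)c3)nn2)/C(C)=C/CC1`, gives 1.21 ug/mL in this assay. Compound 2, with the structure `COc1ccc(/C=C/C(=O)c2ccc(OCCCN3C(=O)/C=C/C(C)(C)C/C=C(\C)CC/C=C/3C)cc2)cc1`, gives 3.17 ug/mL in this assay, which is the higher of the two numbers; the gap between compound 2 and compound 1 lies beyond the usual scatter, so compound 2 is the weaker of the two measured compounds.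

Compound 3, with the structure `COc1cccc(/C=C/C(=O)c2ccc(OCCCN3C(=O)/C=C/C(C)(C)C/C=C(\C)CC/C=C/3C)cc2)c1`, is the next compound to be considered. It is built from the same atoms as compound 2, joined differently: the change is 3-methoxyphenyl in place of 4-methoxyphenyl on a double-bonded chain carbon bound to a double-bonded chain carbon. Within the data shown here, the two measured compounds differ in many places at once, so no single comparable step from one measured compound to another is available to guide the expectation. A rearrangement of this kind, where only the point of attachment of one small group on an outer ring changes, is expected to leave the number for compound 3 close to that of compound 2, with a step of a 1.1-fold higher number from compound 2 to compound 3 (0.04 log units; within the scatter) that is expected to stay within the scatter. Compound 3 is therefore expected to give about 3.5 ug/mL in this assay, within a range from 1.5 ug/mL to 8 ug/mL.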

Compound 3, half-maximal inhibitory concentration: 1.37 ug/mL
Beside the measured number, compound 3's estimate is 2.6-fold (0.41 log units) above it; measured number outside the range, below it.
By their numbers in this assay, from the lowest: compounds 1 and 3 (each within the scatter of the next); then compound 2.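

In this assay, putting 3-methoxyphenyl in place of 4-methoxyphenyl on a double-bonded chain carbon bound to a double-bonded chain carbon gives a 2.3-fold lower number from compound 2 to compound 3 (0.36 log units; beyond the scatter), so at this position the lower number, and with it the stronger inhibition, goes with the 3-methoxyphenyl group. Among these compounds, this is the first comparison that isolates one change, and it shows that the read-out can respond to where the methoxy group is attached on the outer ring, even though the two groups have the same heavy atoms, the same ring and the same count of hydrogen-bond acceptors. No measurement shown here explains the shift.

The compounds shown leave open whether another group on this outer ring, such as an amine or a carboxylic acid in place of the methoxy group, would lower the number further or raise it. They also leave open whether the same move of the methoxy group would give a similar step on another core, such as the core of compound 1, since this single pair cannot show how far the result extends.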